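The source may hold more compounds than are shown below. What is called first, only, known or untested is meant among the compounds shown, and "the series" means these compounds.

Within the data shown here, in a physicochemical assay for lipophilicity (on this read-out lower numbers stand for lower lipophilicity and higher numbers for higher lipophilicity), compound 1 `C=C(c1cccc2ccccc12)C1CCC2(CC1)COC(Nc1ccccc1)OO2` gives 5.59, the lower of the two numbers so far, and compound 2 `C=C(c1cccc2ccccc12)C1CCC2(CC1)COC(Nc1ccc(Cl)cc1)OO2` gives 6.15. That one measured step, chloro in place of hydrogen on an aromatic carbon, is modest: a number 0.56 log units higher from compound 1 to compound 2 (beyond the scatter). Compound 3 `C=C(c1ccc2ccccc2c1)C1CCC2(CC1)COC(Nc1ccccc1)OO2` has not been measured yet. It has the same atoms as compound 1, joined differently: naphthalen-2-yl in place of naphthalen-1-yl on a double-bonded chain carbon bound to a saturated ring carbon, on a double-bonded chain carbon bound to a saturated ring carbon. The chloro step bears on this only loosely, since it adds a new atom and compound 3 adds none. Among the measured compounds shown here, no measured pair compares naphthalen-1-yl with naphthalen-2-yl, so no step beyond the scatter is expected in this assay. The expected change is small: a number 0.06 log units higher from compound 1 to compound 3 (within the scatter). For compound 3, the estimated value is 5.65, with an expected range from 5.25 to 6.05.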

Compound 3, partition coefficient: 5.59
Beside the measured number, compound 3's estimate is 0.06 log units above it, within the range that was stated.
By their numbers in this assay, from the lowest: compounds 1 and 3 (each within the scatter of the next); then compound 2.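

In this assay, the swap of naphthalen-1-yl for naphthalen-2-yl on a double-bonded chain carbon bound to a saturated ring carbon gives no change at the digits printed from compound 1 to compound 3 (within the scatter) for this pair. The earlier chloro step changed a different place and added an atom, giving a number 0.56 log units higher from compound 1 to compound 2 (beyond the scatter), whereas this step shows that changing only how the naphthalene is attached, with the same atoms, leaves the two compounds indistinguishable on this read-out. Nothing measured here offers an explanation for this result.

Going by these compounds, whether the chloro step would read the same on compound 3 remains open. Also open, on these data alone, is how this assay would read with a different group at this place, such as a pyridine ring or a carboxylic acid, instead of either naphthalene.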